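The source may report more compounds than this note shows. Statements on the series, on what has been measured and on what is new or still open speak of the compounds shown alone.

Measured in a functional assay on CHO cells for agonist activity at Free fatty acid receptor 1 (Homo sapiens), read by calcium flux; on this read-out higher numbers stand for an effect only at larger amounts of compound and lower numbers for an effect already at smaller amounts:
Compound 1 `O=C(O)CCc1ccc(OCc2nnc(C(=O)Nc3ccccc3)s2)cc1` gives 1060 nM.
Compound 2 `Cc1cccc(NC(=O)c2nnc(COc3ccc(CCC(=O)O)cc3)s2)c1` gives 1770 nM.
Compound 3 `O=C(O)CCc1ccc(OCc2nnc(C(=O)Nc3ccc(Cl)cc3)s2)cc1` gives 3690 nM.

Compound 3 stands with the highest number of the three in this assay. Its nearest neighbour is compound 2, through the step of a 2.1-fold higher number from compound 2 to compound 3 (0.32 log units; beyond the scatter), and its furthest is compound 1, through the step of a 3.5-fold higher number from compound 1 to compound 3 (0.54 log units; beyond the scatter).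

Compound 4 `O=C(O)CCc1ccc(OCc2nnc(C(=O)Nc3cccc(F)c3)s2)cc1` differs from compound 3 in one place: 3-fluorophenyl in place of 4-chlorophenyl on an amide-type nitrogen. For the measured compounds named here, two measured steps bear on this change. The step of a 3.5-fold higher number from compound 1 to compound 3 (0.54 log units; beyond the scatter) shows what the chloro on the aromatic carbon brought relative to the unsubstituted phenyl, and the step of a 2.1-fold higher number from compound 2 to compound 3 (0.32 log units; beyond the scatter) shows that the 3-methylphenyl on the amide-type nitrogen sat at a lower number than the 4-chlorophenyl. The step of a 1.7-fold higher number from compound 1 to compound 2 (0.22 log units; within the scatter) lay within the scatter. Since the 3-fluorophenyl resembles the 3-methylphenyl of compound 2 rather than the 4-chlorophenyl of compound 3, a return toward the numbers of compound 1 and compound 2 is expected, a modest step to a lower number. Compound 4 is therefore estimated at 1400 nM, within a range from 700 nM to 3000 nM, which means an expected step of a 2.6-fold lower number from compound 3 to compound 4 (0.42 log units; beyond the scatter).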

Compound 4, half-maximal effective concentration: 1190 nM
Compound 4: the middle estimate sits 1.2-fold (0.07 log units) above what was measured, and the stated range covers the measured number.
By their numbers in this assay, from the lowest: compounds 1, 4 and 2 (each within the scatter of the next); then compound 3.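

In this assay the 3-fluorophenyl on the amide-type nitrogen takes the number back down from that of the 4-chlorophenyl, with a 3.1-fold lower number from compound 3 to compound 4 (0.49 log units; beyond the scatter) as a modest step. The fluoro cannot be told apart from the other two groups at this place: a 1.5-fold lower number from compound 2 to compound 4 (0.17 log units; within the scatter) and a 1.1-fold higher number from compound 1 to compound 4 (0.05 log units; within the scatter) both lie within the scatter, so among these four compounds only the 4-chlorophenyl of compound 3 stands apart. The data at hand offer no explanation for this pattern.

The step from compound 3 to compound 4 changes both the halogen and where it sits, so a 3-chlorophenyl and a 4-fluorophenyl would be needed to separate the two changes. Also open, on these data alone, is how larger groups on this phenyl, such as a methoxy or a trifluoromethyl, would behave.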